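Aminopyridine series: sulfamoyl to trifluoromethyl on the aryl ring

The compounds below may be only part of what the source reports. "The series", "measured", "known", "first", "only" and "open" are said of these compounds alone.

Compound 1 `COc1ccc(-c2cc(-c3cccc(S(C)(=O)=O)c3)cnc2N)cn1` gives 7.6 mL.min-1.g-1 in an in vitro ADME assay on microsomes from liver (Homo sapiens) for metabolic stability; on this read-out lower numbers stand for slow clearance and higher numbers for fast clearance. Compound 2 `COc1ccc(-c2cc(-c3ccc(S(N)(=O)=O)cc3)cnc2N)cn1` returns only a limit of the assay, < 7 mL.min-1.g-1. Compound 3 `COc1ccc(-c2cc(-c3ccc(S(C)(=O)=O)c(F)c3)cnc2N)cn1` likewise returns a limit, < 7 mL.min-1.g-1. Compound 2 therefore stands at the limit of < 7 mL.min-1.g-1 in this assay, at which 2 of the 3 values shown sit, so no number separates it from compound 3, and the value of compound 1 lies close to that limit. Among the measured compounds shown here, no pair of measured compounds differs in a single place, so nothing measured bears directly on the change considered next. Compound 4 `COc1ccc(-c2cc(-c3ccc(C(F)(F)F)cc3)cnc2N)cn1` carries trifluoromethyl in place of sulfamoyl on an aromatic carbon. In this assay the expected step from compound 2 to compound 4 is an at least 2.1-fold higher number from compound 2 to compound 4 (0.33 log units; beyond the scatter), a move towards faster clearance beyond the usual scatter. Compound 4 is estimated at 15 mL.min-1.g-1, with a range from 7 mL.min-1.g-1 to 40 mL.min-1.g-1.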

Compound 4, intrinsic clearance in microsomes: 6.1 mL.min-1.g-1
For compound 4 the middle estimate is 2.5-fold (0.39 log units) above the measured one; measured number outside the range, below it.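

No step from compound 2 to compound 4 can be read in this assay, because compound 2 returns only a limit: the limit of < 7 mL.min-1.g-1 in this assay, at which 2 of the 4 values shown sit.
The compounds shown leave open how far the intrinsic clearance of compound 2, with sulfamoyl, lies from that of compound 4, with trifluoromethyl.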